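From propylcarbonyl to dimethylcarbamoyl on compound 2

This account rests on a few compounds, and the source may have more. Where it says the series, first, only, none or still open, it means among the compounds named here.

In a functional assay on the whole organism with Mus musculus as the target (on this read-out lower numbers stand for an effect already at smaller amounts and higher numbers for an effect only at larger amounts of compound), compound 2 `CCCC(=O)OC1CCN(c2ccc(-c3ccccc3Cl)nn2)CC1` gives 39 mg/kg while compound 3 `CCCC(=O)OC1CCN(c2ccc(-c3ccc(Cl)cc3Cl)nn2)CC1` gives 31 mg/kg and compound 1 `O=[N+]([O-])c1ccc(-c2ccc(N3CCC(O)CC3)nn2)cc1` gives 54 mg/kg as its number. Compound 2 thus stands among three numbers that all lie within the scatter of one another. Compound 4 `CN(C)C(=O)OC1CCN(c2ccc(-c3ccccc3Cl)nn2)CC1` awaits measurement in this assay and differs from compound 2 by dimethylamino in place of propyl on a carbonyl carbon on the shared core: dimethylamino in place of propyl on a carbonyl carbon. Going by the values given here, the one measured step (a 1.3-fold lower number from compound 2 to compound 3 (0.10 log units; within the scatter)) is chloro in place of hydrogen on an aromatic carbon. That step lies elsewhere in the structure and stays within the scatter, so it bears on the new change only indirectly. Among the compounds with values here, compound 1 differs from compound 2 in more than one place and offers no single step. No step beyond the scatter is expected in this assay and the estimated change is a 1.1-fold higher number from compound 2 to compound 4 (0.03 log units; within the scatter) with nothing measured at this place. Compound 4 is expected at 42 mg/kg with an estimated range of 20 mg/kg to 85 mg/kg in this read-out.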

Compound 4, dose for half-maximal effect: 1.6 mg/kg
Compound 4: the middle estimate sits 26-fold (1.42 log units) above what was measured; the whole stated range lies above it.
By their numbers in this assay, from the lowest: compound 4; then compounds 3, 2 and 1 (each within the scatter of the next).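

Dimethylamino in place of propyl on a carbonyl carbon gives the first step beyond the scatter in this series: in this assay, it produces a 24-fold lower number from compound 2 to compound 4 (1.39 log units; beyond the scatter). The chloro change elsewhere on the shared core stays within the scatter at a 1.3-fold lower number from compound 2 to compound 3 (0.10 log units; within the scatter), so this carbonyl substituent is the one place shown where the read-out moves strongly. Nothing available accounts for this step, even though the groups exchanged match in heavy-atom count and neither carries a ring.

The compounds shown leave open whether the step depends on dimethylamino specifically or extends to other nitrogen substituents on this carbonyl carbon, such as methylamino, diethylamino or morpholine. They also leave open whether dimethylamino and the added chloro of compound 3 would combine in one compound.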